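From compound 2 to its 4-bromophenyl analogue, compound 3

The compounds below may be only part of what the source reports. "The series", "measured", "known", "first", "only" and "open" are said of these compounds alone.

Measured in a functional assay on PC-3 cells (Homo sapiens) for inhibition, read by MTT assay, with a stated time of 48 h; on this read-out lower numbers stand for stronger inhibition and higher numbers for weaker inhibition:
compound 1 `COc1cc(N(Cc2nc3ccccc3[nH]2)S(=O)(=O)c2ccccc2)cc(OC)c1OC`: 25500 nM
compound 2 `COc1cc(N(Cc2nc3ccccc3[nH]2)C(=O)c2ccccc2)cc(OC)c1OC`: > 50000 nM (a limit, not a number)

Compound 2 stands at the limit of > 50000 nM in this assay, at which 1 of the 2 values shown sits, so only a limit is known for it. The next compound, compound 3 `COc1cc(N(Cc2nc3ccccc3[nH]2)C(=O)c2ccc(Br)cc2)cc(OC)c1OC`, changes the benzoyl group of compound 2: bromo in place of hydrogen on an aromatic carbon. Bromo takes the place of hydrogen on an aromatic carbon, para to a large group, so that benzoyl becomes (4-bromophenyl)carbonyl.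

For the measured compounds named here, only one measured step bears on this, and only loosely: an at least 1.9-fold higher number from compound 1 to compound 2 (0.29 log units; that floor lies within the scatter). That step exchanged phenylsulfonyl for benzoyl on a nitrogen, and its floor lies within the scatter. Going by the values given here, no measured step covers a bromo. With that single step as the guide, no change beyond the scatter is expected in this assay, and another reading at the limit is more likely than not. The estimated step is an at least 1.1-fold lower number from compound 2 to compound 3 (0.04 log units; that floor lies within the scatter). The value expected for compound 3 is 45000 nM, with an estimated range from 15000 nM to 100000 nM.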

Compound 3, half-maximal inhibitory concentration: 19900 nM
The estimate for compound 3 lay 2.3-fold (0.35 log units) above the measured number; the range from low to high includes it.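

In this assay, bromo in place of hydrogen on an aromatic carbon, para to a large group, gives an at least 2.5-fold lower number from compound 2 to compound 3 (0.40 log units; beyond the scatter), the only step shown in the series that lies beyond the scatter, so this place on the benzoyl group does respond to substitution. That step gives a floor rather than a size because compound 2 carries only a limit: the limit of > 50000 nM in this assay, at which 1 of the 3 values shown sits. With (4-bromophenyl)carbonyl in place of phenylsulfonyl on the nitrogen, the result is a 1.3-fold lower number from compound 1 to compound 3 (0.11 log units; within the scatter), so these two groups cannot be told apart in this assay.

As far as these compounds go, it stays open whether the step belongs to bromo in particular or would also come with chloro, methoxy or an amine on the same aromatic carbon. Also open, from the compounds shown here alone, is whether 4-bromophenyl in place of phenyl on the phenylsulfonyl group of compound 1 would give a step of similar size, which would show whether the bromo step carries over from the benzoyl series to the sulfonyl series.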